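The source may report more compounds than this note shows. Statements on the series, on what has been measured and on what is new or still open speak of the compounds shown alone.

Compound 1, `COC(=O)c1cc(-c2cccc(NC(=O)c3ccc(/C=C/C(=O)c4cccc(Br)c4)cc3)c2)on1`: in an ADME assay on Vero cells (Chlorocebus sabaeus) for cytotoxicity, read by MTT assay, with a stated time of 72 h (a lower number here means that less compound is tolerated, a higher number that more compound is tolerated), compound 1 gives > 100 ug/mL, which is a limit of the assay rather than a number.
Compound 2, `COC(=O)c1cc(-c2cccc(NC(=O)c3ccc(/C=C/C(=O)c4ccc(OC)c(OC)c4)cc3)c2)on1`: in this assay compound 2 gives > 50 ug/mL, which is also a limit rather than a number.

Among the measured compounds shown here, compound 2 therefore stands at a limit, and the only comparison available to it, the step that the two limits leave unreadable from compound 1 to compound 2, cannot be sized because the limit of > 100 ug/mL in this assay, at which 1 of the 2 values shown sits, and the limit of > 50 ug/mL in this assay, at which 1 of the 2 values shown sits, both cap the values. Compound 3, `COC(=O)c1cc(-c2cccc(NC(=O)c3ccc(/C=C/C(=O)c4ccccc4Cl)cc3)c2)on1`, differs from compound 2 by 2-chlorophenyl in place of 3,4-dimethoxyphenyl on a carbonyl carbon. For the measured compounds named here, the one measured step at this position is a step that the two limits leave unreadable from compound 1 to compound 2, and its size is not readable, so there is no ground to expect a step beyond the usual scatter in this assay in either direction. Compound 3 is expected to give about 80 ug/mL in this assay, with a range from 30 ug/mL to 160 ug/mL. The expected step is a step that the limit leaves unreadable from compound 2 to compound 3, and a further limit rather than a number is the likeliest outcome for compound 3.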

Compound 3, half-maximal cytotoxic concentration: > 25 ug/mL
Compound 3: only a limit was reported; the forecaster's own chance of this, stated with the estimate: 70%; the middle value is on the limit's open side.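

Compound 3 gives > 25 ug/mL, which is a limit and not a number. The steps from compound 1 to compound 3 and from compound 2 to compound 3 cannot be read. As far as these compounds go, it remains open whether 3-bromophenyl, 3,4-dimethoxyphenyl and 2-chlorophenyl on the carbonyl carbon differ at all in this assay.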